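Notes on the aryl group at the imine carbon toward compound 4

This account rests on a few compounds, and the source may have more. Where it says the series, first, only, none or still open, it means among the compounds named here.

Among the compounds with values here, compound 3 `COc1ccccc1C1=NN(C(=S)Nc2ccccc2)C(c2ccc3c(c2)OCCO3)C1` is the one member of the set with a number rather than a limit: in a functional assay on HT-29 cells (Homo sapiens) for antiproliferative activity, read by MTT assay, with a stated time of 48 h (on this read-out higher numbers stand for weaker inhibition of growth and lower numbers for stronger inhibition of growth), compound 3 gives 30500 nM. Compound 1 `CSc1ccc(C2=NN(C(=S)Nc3ccccc3)C(c3ccc4c(c3)OCCO4)C2)cc1` returns only a limit of this assay, > 200000 nM. Compound 2 `S=C(Nc1ccccc1)N1N=C(c2ccccc2Br)CC1c1ccc2c(c1)OCCO2` likewise returns only a limit, > 200000 nM. The two measured steps that end at compound 3 are readable in one direction only, an at least 6.5-fold lower number from compound 1 to compound 3 (0.81 log units; beyond the scatter) and an at least 6.5-fold lower number from compound 2 to compound 3 (0.81 log units; beyond the scatter), both resting on (the limit of > 200000 nM in this assay, at which 2 of the 3 values shown sit). The step between compound 1 and compound 2 is a step that the two limits leave unreadable from compound 1 to compound 2.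

Compound 4 `Cc1ccc(C2=NN(C(=S)Nc3ccccc3)C(c3ccc4c(c3)OCCO4)C2)cc1C` differs from compound 3 by 3,4-dimethylphenyl in place of 2-methoxyphenyl on a carbon with a double bond to nitrogen. Both measured steps bear on this change, since each shows that an aryl group other than 2-methoxyphenyl on that carbon sits at the limit, while 2-methoxyphenyl alone gives a measurable number. 3,4-Dimethylphenyl is a third such aryl group, so the expected direction is toward a higher number in this assay, and a step of the size of a 4.9-fold higher number from compound 3 to compound 4 (0.69 log units; beyond the scatter) is estimated, with a real chance that only a limit is reported. Compound 4 is expected at 150000 nM, in the range 30000 nM to 400000 nM.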

Compound 4, concentration for 50% growth inhibition: 133000 nM
Estimate against measurement, compound 4: 1.1-fold (0.05 log units) above; low and high end bracket the measured number.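

In this assay, compound 4 is a second member of the set with a number rather than a limit, so a change away from 2-methoxyphenyl on the carbon with a double bond to nitrogen can now be given a size: a 4.4-fold higher number from compound 3 to compound 4 (0.64 log units; beyond the scatter). The series at this position is therefore not split into 2-methoxyphenyl on one side and limits on the other, since 3,4-dimethylphenyl also gives a measurable number, though a modestly higher one. Against the two compounds that return only limits, the steps are floors, an at least 1.5-fold lower number from compound 2 to compound 4 (0.17 log units; that floor lies within the scatter) and an at least 1.5-fold lower number from compound 1 to compound 4 (0.17 log units; that floor lies within the scatter), so compound 4 cannot be set apart from either, and both readings rest on a limit: the limit of > 200000 nM in this assay, at which 2 of the 4 values shown sit.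

What the compounds shown leave open is whether the lower number of compound 3 belongs to the methoxy group as such or to where it sits on the phenyl ring, a question that 4-methoxyphenyl on the same carbon would address. Also open, going by these compounds, is whether a different kind of group there, such as 4-aminophenyl or 4-carboxyphenyl, would give a number at all in this assay.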